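Moving the Bromine Around the Outer Phenyl Ring

The source may report more compounds than this note shows. Statements on the series, on what has been measured and on what is new or still open speak of the compounds shown alone.

Of the compounds shown here, three built on a shared core have been tested so far in a functional assay on T47D cells (Homo sapiens) for inhibition, read by CCK-8 assay, with a stated time of 72 h, tested at 1 uM; a higher number here means more inhibition of growth at the concentration tested, a lower number less inhibition of growth. Compound 1 `CN(C)C(=O)c1cc2cnc(Nc3ccc(NC(=O)C4(C(=O)Nc5ccccc5F)CC4)cc3)nc2n1C1CCCC1` gives 85.2%, compound 2 `CN(C)C(=O)c1cc2cnc(Nc3ccc(NC(=O)C4(C(=O)Nc5ccc(F)cc5)CC4)cc3F)nc2n1C1CCCC1` gives 6.3%, and compound 3 `CN(C)C(=O)c1cc2cnc(Nc3ccc(NC(=O)C4(C(=O)Nc5ccc(Br)cc5)CC4)cc3)nc2n1C1CCCC1` gives 21.1%. Compound 3 thus stands second highest of the three values, with the numbers of compound 2 and of compound 1 on either side of it, each beyond the scatter.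

Within the data shown here, the one single-place step measured so far is a number 64.1 percentage points lower from compound 1 to compound 3 (beyond the scatter), a large fall. Compound 2 differs from compound 3 in more than one place, so only its value can be set beside that of compound 3.

Compound 4 `CN(C)C(=O)c1cc2cnc(Nc3ccc(NC(=O)C4(C(=O)Nc5cccc(Br)c5)CC4)cc3)nc2n1C1CCCC1` differs from compound 3 in one place: 3-bromophenyl in place of 4-bromophenyl on an amide-type nitrogen. Among the measured compounds shown here, no measured step moves the bromine around this outer ring, so there is no direct guide. As far as these compounds go, because the step of a number 64.1 percentage points lower from compound 1 to compound 3 (beyond the scatter) shows that what sits on this ring can matter greatly, a change is plausible, but its direction is unknown, and the expectation is a step of a number 8.9 percentage points higher from compound 3 to compound 4 (within the scatter) that may stay within the scatter. Compound 4 is expected to reach about 30%, within roughly 5% to 60%.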

Compound 4, percent growth inhibition at one concentration: 29.1%
Estimate against measurement, compound 4: 0.9 percentage points above; the range from low to high includes it.
By their numbers in this assay, from the lowest: compound 2; then compounds 3 and 4 (each within the scatter of the next); then compound 1.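

In this assay, moving the bromine from the 4-bromophenyl to the 3-bromophenyl arrangement gives a number 8 percentage points higher from compound 3 to compound 4 (within the scatter) and so does not separate these two placements. Changing the group on the amide-type nitrogen from 2-fluorophenyl to 3-bromophenyl gives a number 56.1 percentage points lower from compound 1 to compound 4 (beyond the scatter) and thus a large fall, which compound 3 showed for 4-bromophenyl, now appears with the other bromine placement as well. No measurement at hand explains either step.

The compounds shown leave open whether the high value of compound 1 depends on the halogen or on its place, since 2-bromophenyl and 3-fluorophenyl do not appear among them. They also leave open how this ring would respond to something other than a halogen, such as an amine or a carboxylic acid.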